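The source may report more compounds than this note shows. Statements on the series, on what has been measured and on what is new or still open speak of the compounds shown alone.

Three compounds sharing one core have been run in a functional assay on HepG2 cells (Homo sapiens) for antiproliferative activity, read by MTT assay, with a stated time of 24 h; on this read-out higher numbers stand for weaker inhibition and lower numbers for stronger inhibition. Compound 1 `O=c1[nH]cc(S(=O)(=O)Nc2cccc(-c3cn(-c4ccccc4F)nn3)c2)c(=O)[nH]1` gives 13900 nM. Compound 2 `Cc1ccccc1-n1cc(-c2ccc(NS(=O)(=O)c3c[nH]c(=O)[nH]c3=O)cc2)nn1` gives 14500 nM, and the numbers for compound 1 and compound 2 sit within the scatter of each other. For compound 3 `O=c1[nH]cc(S(=O)(=O)Nc2ccc(-c3cn(-c4cccc(F)c4)nn3)cc2)c(=O)[nH]1` the assay reports only a limit, > 20000 nM. Compound 3 thus stands on a floor rather than a number, and the step of an at least 1.3-fold higher number from compound 2 to compound 3 (0.13 log units; that floor lies within the scatter) is known only as a minimum, since the limit of > 20000 nM in this assay, at which 1 of the 3 values shown sits, hides its true size.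

Compound 4 `O=c1[nH]cc(S(=O)(=O)Nc2ccc(-c3cn(-c4ccc(Cl)cc4)nn3)cc2)c(=O)[nH]1` differs from compound 3 in one place: 4-chlorophenyl in place of 3-fluorophenyl on an aromatic nitrogen. For the measured compounds named here, the only measured step that bears on this comparison is the exchange of a group on the same aromatic nitrogen, an at least 1.3-fold higher number from compound 2 to compound 3 (0.13 log units; that floor lies within the scatter), whose floor lies within the scatter. Going by the values given here, no measured compound carries 4-chlorophenyl, so nothing shows how that group behaves here. On this basis the step of a number no higher from compound 3 to compound 4 (the limit leaves the size open) is expected to be small, likely within the scatter, with a real chance that the assay again reports only a limit for compound 4. The value of compound 4 in this assay is estimated at 20000 nM, within a range from 9000 nM to 45000 nM.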

Compound 4, half-maximal inhibitory concentration: 1980 nM
Compound 4: the middle estimate sits 10-fold (1.00 log units) above what was measured; measured number below the stated range.
By their numbers in this assay, from the lowest: compound 4; then compounds 1 and 2 (each within the scatter of the next). At a limit, above all of these: compound 3.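

In this assay, for the compounds shown here, the group on this aromatic nitrogen turns out to matter, which the earlier compounds could not show: 4-chlorophenyl in place of 3-fluorophenyl gives a step beyond the scatter (an at least 10-fold lower number from compound 3 to compound 4 (1.00 log units; beyond the scatter)), and 4-chlorophenyl in place of 2-methylphenyl also gives one (a 7.3-fold lower number from compound 2 to compound 4 (0.86 log units; beyond the scatter)). The 3-fluorophenyl and 4-chlorophenyl groups have the same count of heavy atoms, neither has hydrogen-bond donors or acceptors, and neither carries a net charge, so these counts do not separate them, although the assay does. The step to compound 4 from compound 3 can be read only as a minimum, since compound 3 stands at a limit of the assay: the limit of > 20000 nM in this assay, at which 1 of the 4 values shown sits.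

The exchange changes both the halogen and its place on the phenyl ring, so the compounds shown do not tell which of the two carries the step; 4-fluorophenyl and 3-chlorophenyl on the same nitrogen would separate them. They also leave open how this position would respond to a phenyl ring bearing an amine or a carboxylic acid.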